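From 3,5-dimethoxyphenyl to 2-chloro-4-fluorophenyl: estimating compound 4

The compounds below may be only part of what the source reports. "The series", "measured", "known", "first", "only" and "open" are said of these compounds alone.

The compounds tested so far in a functional assay on HeLa cells (Homo sapiens) for cytotoxicity, read by MTT assay, with a stated time of 72 h (a lower number here means a stronger inhibitor, a higher number a weaker inhibitor), are these:
Compound 1 `COc1cc2ncnc(Nc3ccc(F)c(Cl)c3)c2cc1NC(=O)/C=C/c1ccc(F)cc1Cl` has the entry "not determined" (no result reported) with no number
Compound 2 `COc1ccc(/C=C/C(=O)Nc2cc3c(Nc4ccc(F)c(Cl)c4)ncnc3cc2O[C@H]2CCOC2)c(OC)c1` gives 26500 nM
Compound 3 `COc1cc(/C=C/C(=O)Nc2cc3c(Nc4ccc(F)c(Cl)c4)ncnc3cc2O[C@H]2CCOC2)cc(OC)c1` gives 34300 nM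

Within the data shown here, compound 3 is one of only two compounds with a number, and its value lies within the scatter of that of compound 2. Among the measured compounds shown here, the single measured step is a 1.3-fold higher number from compound 2 to compound 3 (0.11 log units; within the scatter) and it only exchanges 2,4-dimethoxyphenyl for 3,5-dimethoxyphenyl.

Compound 4 `O=C(/C=C/c1ccc(F)cc1Cl)Nc1cc2c(Nc3ccc(F)c(Cl)c3)ncnc2cc1O[C@H]1CCOC1` has not yet been measured. Its difference from compound 3 is this: 2-chloro-4-fluorophenyl in place of 3,5-dimethoxyphenyl on a double-bonded chain carbon bound to a double-bonded chain carbon and so the dimethoxyphenyl group gives way to 2-chloro-4-fluorophenyl on the same chain carbon. For the measured compounds named here, the one measured step bears on this only loosely, since both of its compounds carry dimethoxyphenyl groups. Compound 1 does carry 2-chloro-4-fluorophenyl, but it offers no number, so no measurement shows what this group does here. No clear direction can therefore be drawn from the data, and no change beyond the scatter is expected. The expected step in this assay is a 1.7-fold lower number from compound 3 to compound 4 (0.23 log units; within the scatter) as a cautious estimate. For compound 4 the estimated value is 20000 nM with an expected range from 6000 nM to 50000 nM around it.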

Compound 4, half-maximal inhibitory concentration: 37500 nM
Estimate against measurement, compound 4: 1.9-fold (0.27 log units) below; the range from low to high includes it.
By their numbers in this assay, from the lowest: compounds 2, 3 and 4 (each within the scatter of the next).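

In this assay, putting 2-chloro-4-fluorophenyl on a double-bonded chain carbon bound to a double-bonded chain carbon gives a 1.1-fold higher number from compound 3 to compound 4 (0.04 log units; within the scatter) and also a 1.4-fold higher number from compound 2 to compound 4 (0.15 log units; within the scatter) when it replaces 2,4-dimethoxyphenyl. Among these compounds, the earlier step compared only two dimethoxyphenyl groups, whereas this change swaps the methoxy groups for chlorine and fluorine and removes the hydrogen-bond acceptors counted on 3,5-dimethoxyphenyl, and still no step leaves the scatter, so among compounds 2, 3 and 4 the number does not follow the identity of these substituents on the phenyl ring. No measurement shown here accounts for this result.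

Going by these compounds, all three numbered compounds carry a substituted phenyl at this place, so it remains open whether a dimethylamino group, a carboxylic acid or a longer alkyl chain there would move the number beyond the scatter. On these data alone, it also remains open whether any change away from this place, on the shared core or on the group that compounds 2, 3 and 4 carry in common with it, would shift the number in this assay by more than these steps do.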